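The compounds below may be only part of what the source reports. "The series", "measured", "known", "first", "only" and "open" are said of these compounds alone.

For the measured compounds named here, compound 2, `Cc1cc(C(=O)O)c(C)n1-c1cccc(C2CC2)c1`, is one of two compounds measured in an assay on cells for inhibition of Palmitoleoyl-protein carboxylesterase NOTUM variant C330S (Homo sapiens), read by fluorescence, with a stated time of 40 min; on this read-out higher numbers stand for weaker inhibition and lower numbers for stronger inhibition. In this assay compound 2 gives 580 nM. The other measured compound, compound 1, `Cc1cc(C(=O)O)c(C)n1-c1cccc(C#N)c1F`, gives 630 nM in this assay, and the two numbers sit within the usual scatter of one another, so neither can be placed ahead of the other.

The step from compound 2 leads to compound 3, `Cc1cc(C(=O)O)c(C)n1-c1cccc(C2CC2)c1F`, which differs by fluoro in place of hydrogen on an aromatic carbon. Going by the values given here, no measured pair shows this change directly, so the expected size of the step rests on the two measured compounds alone. Since compound 1 already carries a fluoro on the same ring and gives 630 nM, a large movement in either direction seems unlikely; a step of about a 1.4-fold lower number from compound 2 to compound 3 (0.14 log units; within the scatter) is expected, not beyond the scatter. Compound 3 is therefore estimated at 420 nM, with a range from 150 nM to 1200 nM.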

Compound 3, half-maximal inhibitory concentration: 200 nM
For compound 3 the middle estimate is 2.1-fold (0.32 log units) above the measured one; measured number inside the range.
By their numbers in this assay, from the lowest: compound 3; then compounds 2 and 1 (each within the scatter of the next).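

In this assay, fluoro in place of hydrogen on an aromatic carbon ortho to a cyclopropyl group gives a 2.9-fold lower number from compound 2 to compound 3 (0.46 log units; beyond the scatter) and so shows that this position responds to a single added atom by more than the scatter. With the fluoro held in place, cyclopropyl in place of cyano gives a 3.2-fold lower number from compound 1 to compound 3 (0.50 log units; beyond the scatter) and so separates these two groups, a reading that compounds 1 and 2 could not give, since they differ in more than one place.

As far as these compounds go, it remains open whether chlorine or a methoxy group on the same carbon would give a step like that of fluoro. From the compounds shown here alone, it is also open whether fluoro would have the same effect with an amine or a longer chain in place of the cyclopropyl group. The information available offers no explanation for either step.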